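Moving the Fluorine: From Compound 2 to Compound 4

The source may hold more compounds than are shown below. What is called first, only, known or untested is meant among the compounds shown, and "the series" means these compounds.

Measured compounds in a functional assay on HL-60 cells (Homo sapiens) for antiproliferative activity, read by sulforhodamine B assay, with a stated time of 72 h; on this read-out lower numbers stand for stronger inhibition and higher numbers for weaker inhibition:
compound 1 `FC(F)(F)c1ccccc1NC(=S)N/N=C/c1ccc2ccccc2n1` gives 13200 nM.
compound 2 `Fc1ccccc1NC(=S)N/N=C/c1ccc2ccccc2n1` gives > 100000 nM, a limit of the assay and not a number.
compound 3 `CN(C)C(=S)N/N=C/c1nc2ccccc2s1` gives 3680 nM.

Compound 2 therefore stands at the limit of > 100000 nM in this assay, at which 1 of the 3 values shown sits, the weakest point the numbers shown can record. For the measured compounds named here, the only measured step that touches its neighbourhood is an at least 7.5-fold higher number from compound 1 to compound 2 (0.87 log units; beyond the scatter), which changes the substituent itself, not its position. Compound 4 `Fc1cccc(NC(=S)N/N=C/c2ccc3ccccc3n2)c1` differs from compound 2 by 3-fluorophenyl in place of 2-fluorophenyl on an amide-type nitrogen. Going by the values given here, no measured pair tests such a positional shift, so the size of the step in this assay is unknown; a value near the limit remains the likeliest outcome. Compound 4 is expected to give about 60000 nM, within 10000 nM to 100000 nM, an estimated step of an at least 1.6-fold lower number from compound 2 to compound 4 (0.22 log units; that floor lies within the scatter).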

Compound 4, half-maximal inhibitory concentration: 43800 nM
The estimate for compound 4 lay 1.4-fold (0.14 log units) above the measured number, and the stated range covers the measured number.
By their numbers in this assay, from the lowest: compound 3; then compound 1; then compound 4. At a limit, above all of these: compound 2.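

Compound 2 and compound 4 carry the same atoms, so this pair shows that the choice between 2-fluorophenyl and 3-fluorophenyl on the amide-type nitrogen matters by itself, which the earlier change of substituent could not show: the swap gives an at least 2.2-fold lower number from compound 2 to compound 4 (0.35 log units; beyond the scatter). Only a floor can be stated for this step, since the value of compound 2 is a limit of the assay and not a number: the limit of > 100000 nM in this assay, at which 1 of the 4 values shown sits.

As far as these compounds go, whether trifluoromethyl would respond to the same shift remains open. So does the effect of an amine or a carboxylic acid in place of the fluorine on this phenyl group.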